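The source may report more compounds than this note shows. Statements on the series, on what has been measured and on what is new or still open speak of the compounds shown alone.

Of the compounds shown here, three carrying the same core have been measured in an assay on HeLa cells for displacement of a labelled ligand from 5-hydroxytryptamine receptor 6 (Homo sapiens); on this read-out lower numbers stand for stronger inhibition and higher numbers for weaker inhibition. Compound 1 `CN1CCCC(n2cc(S(=O)(=O)c3ccc(Cl)cc3)c3cccnc32)C1` gives 11.5 nM, compound 2 `CN1CCCC(n2cc(S(=O)(=O)c3cccc(F)c3)c3cccnc32)C1` gives 4.7 nM, and compound 3 `O=S(=O)(c1cc(Cl)cc(Cl)c1)c1cn(C2CCCNC2)c2ncccc12` gives 6.1 nM. For the measured compounds named here, the one measured single-point step, a 2.4-fold lower number from compound 1 to compound 2 (0.39 log units; beyond the scatter), concerns only the ring attached to the sulfonyl sulfur. Compound 3 stands within the usual scatter of both neighbours: its number differs from that of compound 2 and from that of compound 1 by less than repeated measurements would, so no ranking among the three can be drawn from these numbers.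

Compound 4 `CN1CCCC(n2cc(S(=O)(=O)c3cc(Cl)cc(Cl)c3)c3cccnc32)C1` differs from compound 3 in one place: methyl in place of hydrogen on an amine nitrogen in a ring; cut one bond further out, the change reads piperidin-3-yl to 1-methylpiperidin-3-yl. Going by the values given here, no measured pair isolates this change: compounds 1 and 2 already carry the methyl on the ring nitrogen, and compound 3 lacks it, but each also carries a different ring on the sulfonyl sulfur, so the effect of the methyl alone cannot be read from them. Since the measured step bears only on the aryl ring, the expectation in this assay is a step of a 1.0-fold lower number from compound 3 to compound 4 (0.01 log units; within the scatter), no larger than the scatter, in either direction. Compound 4 is therefore estimated at 6 nM, between 2 nM and 18 nM.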

Compound 4, inhibition constant: 3.9 nM
For compound 4 the middle estimate is 1.5-fold (0.19 log units) above the measured one; the range from low to high includes it.
By their numbers in this assay, from the lowest: compounds 4, 2, 3 and 1 (each within the scatter of the next, the first and the last beyond it).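

In this assay, methyl in place of hydrogen on the amine nitrogen in the ring gives a 1.6-fold lower number from compound 3 to compound 4 (0.19 log units; within the scatter) and stays within the scatter, so with the 3,5-dichlorophenyl group on the sulfonyl sulfur, this read-out cannot tell the two forms of that nitrogen apart. With the methyl on that nitrogen in all three compounds, 3,5-dichlorophenyl in place of 4-chlorophenyl gives a 2.9-fold lower number from compound 1 to compound 4 (0.47 log units; beyond the scatter) and lies beyond the scatter, whereas 3,5-dichlorophenyl in place of 3-fluorophenyl gives a 1.2-fold lower number from compound 2 to compound 4 (0.08 log units; within the scatter) and stays within it, so the ring on the sulfur shows a readable step only in the first of these two comparisons. No supporting data are available to explain either result.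

This single pair leaves open whether methyl and hydrogen on that nitrogen would also read alike with a 4-chlorophenyl or 3-fluorophenyl group on the sulfur. It also leaves open how the same nitrogen would read when carrying an ethyl group, an acetyl group or a longer chain such as a benzyl group.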